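Methoxy removal beside a large group: expected step in cytotoxicity

A few compounds are considered here, and "the series" means these few. Any claim that something is new, unique, unknown or untested is made for them only; others in the source may bear on it.

Measured so far in a functional assay on HEp-2 cells (Homo sapiens) for cytotoxicity, read by sulforhodamine B assay, with a stated time of 48 h; on this read-out lower numbers stand for stronger inhibition and higher numbers for weaker inhibition:
compound 1 `CC(=O)N1N=C(c2cccc([N+](=O)[O-])c2)CC1c1ccccc1` gives 8930 nM
compound 2 `COc1ccc(C2CC(c3cccc([N+](=O)[O-])c3)=NN2C(C)=O)cc1` gives 8210 nM
compound 3 `COc1ccc(C2CC(c3cccc4ccccc34)=NN2C(C)=O)c(OC)c1OC` gives 1290 nM

Compound 3 stands lowest of the three; the difference between its core and that of compound 2 is not broken down here. Compound 1 and compound 2 differ in one place: hydrogen in place of methoxy on an aromatic carbon. That step, a 1.1-fold higher number from compound 2 to compound 1 (0.04 log units; within the scatter), is within the scatter, so the methoxy in that place contributes nothing that this assay can resolve.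

Compound 4 `COc1ccc(C2CC(c3cccc4ccccc34)=NN2C(C)=O)cc1OC` is not yet measured. It differs from compound 3 by hydrogen in place of methoxy on an aromatic carbon. For the measured compounds named here, this is the same kind of change as the one from compound 2 to compound 1, but not the same: there the leaving methoxy sat para to a large group, whereas here it sits ortho to a large group, ortho to a methoxy group and meta to a methoxy group. Going by the values given here, the only measured precedent for the change is therefore only loosely comparable, and the remaining two methoxy groups of compound 4 have no measured counterpart.

Resting on the flat step from compound 2 to compound 1 in this assay, the expectation for compound 4 is a small step, a 1.2-fold higher number from compound 3 to compound 4 (0.09 log units; within the scatter), with wide bounds for the differing surroundings of the change. Compound 4 is estimated at 1600 nM in this assay, expected to lie between 700 nM and 4000 nM.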

Compound 4, half-maximal inhibitory concentration: 1030 nM
For compound 4 the middle estimate is 1.6-fold (0.19 log units) above the measured one, and the stated range covers the measured number.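

In this assay hydrogen in place of methoxy on an aromatic carbon gives a 1.3-fold lower number from compound 3 to compound 4 (0.10 log units; within the scatter) and so, on this core as on the core of compound 1, the methoxy that leaves contributes nothing the assay can resolve. Set side by side, the two steps do not differ by more than can be expected from repeated measurement, so this change carries from one core to the other in this series without a resolved difference: the same change on two cores in this assay, a 1.1-fold higher number (0.04 log units; within the scatter) from compound 2 to compound 1 and a 1.3-fold lower number (0.10 log units; within the scatter) from compound 3 to compound 4, 1.4-fold (0.13 log units) apart, within the scatter of two such steps. This shows only that the methoxy can give way to hydrogen on these two cores with no resolved shift in the number, and it rests on two pairs alone; it does not show that the same flat step would hold on a further core, or for a methoxy in any other place on the ring.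

Going by these compounds, what the two methoxy groups that remain on compound 4 contribute stays open, as does whether the ring would tolerate losing them together. Also open, on these data alone, is whether a hydroxyl, an amine or a carboxylic acid in the place of the methoxy would give a step of another size in this assay on either core.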